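The compounds below may be only part of what the source reports. "The series", "measured", "known", "first", "only" and "open" are said of these compounds alone.

Compound 2 `CCOC(=O)c1sc(-c2ccncc2)nc1N1CCC(NCc2ccc(F)cc2)CC1` gives 17.5% in an ADME assay on RAW264.7 cells (Mus musculus) for cytotoxicity, read by MTT assay, with a stated time of 72 h, tested at 50 uM; on this read-out higher numbers stand for more inhibition at the one concentration tested (going by the name of the read-out) and lower numbers for less inhibition. Among the three measured compounds its number is the highest, but the gaps to compound 1 `CCOC(=O)c1sc(-c2ccccn2)nc1N1CCC(NCc2ccc(F)cc2)CC1` with 12.6% and to compound 3 `CCOC(=O)c1sc(-c2ccncc2)nc1N1CCC(NCc2ccc(OCc3ccccc3)cc2)CC1` with 8.04% are both within the scatter. Compound 4 `CCOC(=O)c1sc(-c2ccncc2)nc1N1CCC(NCc2ccc(Cl)c(Cl)c2)CC1` differs from compound 2 by 3,4-dichlorophenyl in place of 4-fluorophenyl on a saturated chain carbon bound to an amine nitrogen. One earlier step changed the same place, fluoro to benzyloxy, and gave a number 9.5 percentage points lower from compound 2 to compound 3 (within the scatter), within the scatter. The other step, a number 4.9 percentage points higher from compound 1 to compound 2 (within the scatter), changed a different part and also stayed within the scatter. Within the data shown here, no measured step moved this assay beyond the scatter, so a step of a number 1.5 percentage points lower from compound 2 to compound 4 (within the scatter) is expected, that is, none beyond the scatter. Compound 4 is estimated at 16%, with a range from 4% to 30%.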

Compound 4, a percentage reported as inhibition, at one concentration (the size of the read-out at that concentration, not a potency): 32.2%
Beside the measured number, compound 4's estimate is 16.2 percentage points below it; measured number outside the range, above it.
By their numbers in this assay, from the lowest: compounds 3, 1 and 2 (each within the scatter of the next); then compound 4.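

In this assay, among these compounds, 3,4-dichlorophenyl in place of 4-fluorophenyl on a saturated chain carbon bound to an amine nitrogen gives a number 14.7 percentage points higher from compound 2 to compound 4 (beyond the scatter), the only measured step beyond the scatter. This position can therefore move the number, which the change from fluoro to benzyloxy did not show. Nothing available explains this rise.

The compounds shown leave open whether a single chlorine, as in 4-chlorophenyl, would give a step of this size. They also leave open how a methoxy group or an amine on the same ring would change the number.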